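Trimming the urea terminus: compound 2 to compound 3

A few compounds are considered here, and "the series" means these few. Any claim that something is new, unique, unknown or untested is made for them only; others in the source may bear on it.

compound 1 `CC(C)OC(=O)NCCS(=O)(=O)NC(=O)c1ccc(Nc2nc(NC3(c4ccc(Cl)cc4)CC3)nc(OCC(F)(F)F)n2)cc1`: 71 nm/s
compound 2 `CC(C)NC(=O)NCCS(=O)(=O)NC(=O)c1ccc(Nc2nc(NC3(c4ccc(Cl)cc4)CC3)nc(OCC(F)(F)F)n2)cc1`: 45 nm/s

Of the compounds shown here, two on a shared core have been measured in a physicochemical assay for permeability, using PAMPA, at pH 7.4; a lower number here means that the compound crosses the layer more slowly, a higher number that the compound crosses the layer faster. Compound 2 sits at one end of the two numbers, yet a 1.6-fold lower number from compound 1 to compound 2 (0.20 log units; within the scatter), so the pair cannot be told apart on this evidence.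

Compound 3 `CNC(=O)NCCS(=O)(=O)NC(=O)c1ccc(Nc2nc(NC3(c4ccc(Cl)cc4)CC3)nc(OCC(F)(F)F)n2)cc1` differs from compound 2 in a single place: methyl in place of isopropyl on an amide-type nitrogen. Among the measured compounds shown here, no measured step touches this end of the molecule. For the measured compounds named here, the only step available, from compound 1 to compound 2, concerns a different position on the same side chain and itself stays within the scatter, so it offers no direct guide to what the shorter chain will do.

Going by the values given here, with no precedent of its own, the change is expected to produce at most a modest shift in this assay, tending downward if anywhere, and the step from compound 2 to compound 3 is estimated as a 1.4-fold lower number from compound 2 to compound 3 (0.15 log units; within the scatter). Compound 3 is therefore expected to give about 32 nm/s, with a plausible range from 14 nm/s to 70 nm/s.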

Compound 3, apparent permeability: 40 nm/s
Compound 3: the middle estimate sits 1.3-fold (0.10 log units) below what was measured; measured number inside the range.
By their numbers in this assay, from the lowest: compounds 3, 2 and 1 (each within the scatter of the next).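

In this assay, among the compounds shown here, the methyl and isopropyl groups on the amide-type nitrogen now have a direct comparison, which the earlier compounds did not provide: the change gives a 1.1-fold lower number from compound 2 to compound 3 (0.05 log units; within the scatter) and so cannot be told from no change on this evidence. Compound 3 also allows methylamino to be compared with isopropoxy on the carbonyl carbon, a swap that alters both the atom attached to the carbonyl and the size of the terminal group, and this gives a 1.8-fold lower number from compound 1 to compound 3 (0.25 log units; within the scatter) and therefore also stays unresolved. Nothing here offers an explanation for these numbers.

The compounds shown leave open whether any other group on this nitrogen, such as a phenyl ring, a longer chain ending in an amine, or a chain ending in a carboxylic acid, would give a step beyond the scatter in this assay. They also leave open whether replacing the urea terminus altogether, for example with a simple amide or a sulfonamide, would separate from these three compounds on the shared core.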